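Working notes on three measured analogues and one pending

The compounds below may be only part of what the source reports. "The series", "measured", "known", "first", "only" and "open" are said of these compounds alone.

Measured so far:
compound 1 `CC1=C(C(=O)OCC(C)C)C(c2cccs2)NC(=O)N1` — 2130 nM
compound 2 `CCCC(=O)C1=C(C)NC(=O)NC1c1ccco1` — 807 nM
compound 3 `CC1=C(C(=O)CC(C)C)C(c2ccsc2)NC(=O)N1` — 1000 nM

In an assay on membranes from HEK293 cells for displacement of a labelled ligand from adenosine receptor A2b (Homo sapiens), read by scintillation counting, with a stated time of 30 min (on this read-out lower numbers stand for stronger inhibition and higher numbers for weaker inhibition), compound 2 gives the lowest number of the three. Compound 3 sits within the scatter of it, so no order between those two can be read; compound 1 lies beyond the scatter, with a higher number than compound 2.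

Compound 4 `CC1=C(c2ncc(C)o2)C(c2ccco2)NC(=O)N1` is not yet measured. It carries 5-methyl-1,3-oxazol-2-yl in place of propylcarbonyl on a double-bonded ring carbon. Within the data shown here, no pair in the set shows the effect of exchanging a ketone for a five-membered aromatic ring, so no direct guide exists. The expectation is a step from compound 2 to compound 4 of a 1.4-fold higher number from compound 2 to compound 4 (0.13 log units; within the scatter), most likely small and not clearly beyond the scatter. Compound 4 is estimated at 1100 nM, with a range from 300 nM to 4000 nM.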

Compound 4, inhibition constant: 905 nM
Estimate against measurement, compound 4: 1.2-fold (0.08 log units) above; the range from low to high includes it.
By their numbers in this assay, from the lowest: compounds 2, 4 and 3 (each within the scatter of the next); then compound 1.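

In this assay, 5-methyl-1,3-oxazol-2-yl in place of propylcarbonyl on a double-bonded ring carbon gives a 1.1-fold higher number from compound 2 to compound 4 (0.05 log units; within the scatter). At this position, then, a five-membered aromatic ring with 2 hetero atoms can stand in place of the carbonyl chain with no readable change in the number. Nothing at hand explains why the two groups read alike. Open, going by these compounds, is how a carboxylic acid, an amine or a longer chain would read at this position. Also open, on these data alone, is whether the same exchange reads alike with a group other than furan-2-yl on the core.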